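The compounds below may be only part of what the source reports. "The series", "measured", "known", "first", "only" and "open" are said of these compounds alone.

In an ADME assay on microsomes (Rattus norvegicus) for metabolic stability (on this read-out higher numbers stand for a longer-lived compound and lower numbers for a shorter-lived compound), compound 1 `O=C(c1ccccc1)N1CCC(C(=O)N2N=CCC2c2ccccc2)CC1` gives 0.0833 h. Compound 2 `O=C(c1c[nH]nn1)N1CCC(C(=O)N2N=CCC2c2ccccc2)CC1` gives > 2.75 h, and this is a limit of the assay, not a number. Its standing is known only as the limit of > 2.75 h in this assay, at which 1 of the 2 values shown sits. Going by the values given here, the one measured step is an at least 33-fold higher number from compound 1 to compound 2 (1.51 log units; beyond the scatter), a large change beyond the scatter, made by putting 1H-1,2,3-triazol-4-yl in place of phenyl on a carbonyl carbon.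

Compound 3 `O=C(c1cocn1)N1CCC(C(=O)N2N=CCC2c2ccccc2)CC1` keeps the core of compound 2 and carries 1,3-oxazol-4-yl in place of 1H-1,2,3-triazol-4-yl on a carbonyl carbon. Both groups are five-membered aromatic rings, so this swap is not the one already measured, and that step bears on it only indirectly by marking out the span available. A modest fall in this assay is expected, with the result staying well clear of compound 1 at 0.0833 h. The expected change is an at least 2.7-fold lower number from compound 2 to compound 3 (0.43 log units; beyond the scatter), a lower number and a step of moderate size. For compound 3 the estimated half-life is 1 h, with an expected range of 0.3 h to 3 h.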

Compound 3, half-life: 0.533 h
For compound 3 the middle estimate is 1.9-fold (0.27 log units) above the measured one; the range from low to high includes it.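

A second five-membered aromatic ring on the carbonyl carbon also gives a gain over phenyl in this assay and shows a 6.4-fold higher number from compound 1 to compound 3 (0.81 log units; beyond the scatter) as a step of modest size, so the gain seen earlier is not confined to the triazole among the groups shown. The two five-membered rings are nevertheless not interchangeable at this position, with an at least 5.1-fold lower number from compound 2 to compound 3 (0.71 log units; beyond the scatter) as the step for 1,3-oxazol-4-yl in place of 1H-1,2,3-triazol-4-yl. On these data alone, compound 2 is held only as a limit of the assay, so that step has a lower bound and its full size is unknown: the limit of > 2.75 h in this assay, at which 1 of the 3 values shown sits.

Compound 2 and compound 3 differ at once in the hydrogen-bond donor and in the hetero atoms of the ring, so the pair cannot tell which of these differences goes with the step. Also open, as far as these compounds go, is where a 1H-pyrazol-4-yl or pyridin-3-yl group on the same carbonyl carbon would fall relative to phenyl, 1,3-oxazol-4-yl and 1H-1,2,3-triazol-4-yl.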